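A few compounds are considered here, and "the series" means these few. Any claim that something is new, unique, unknown or untested is made for them only; others in the source may bear on it.

Of the compounds shown here, three have been measured in a functional assay on MCF7 cells (Homo sapiens) for antiproliferative activity, with a stated time of 5 days; on this read-out lower numbers stand for stronger inhibition and higher numbers for weaker inhibition. Compound 1 `CCCCc1ccc2[nH]c(-c3ccc(OC)cc3)c(C=O)c2c1` gives 22 nM, compound 2 `CCCCc1ccc2[nH]c(-c3ccc(OC)cc3)c(/C=N/NC(=O)c3ccc(F)cc3)c2c1` gives 84 nM and compound 3 `COc1ccc(-c2[nH]c3ccc(C)cc3c2/C=N/NC(=O)c2ccncc2)cc1` gives 200 nM. Compound 2 thus stands in the middle, with both gaps beyond the usual scatter. Compound 4 `CCCCc1ccc2[nH]c(-c3ccc(OC)cc3)c(/C=N/NC(=O)c3cccnc3)c2c1` departs from compound 2 in one place: pyridin-3-yl in place of 4-fluorophenyl on a carbonyl carbon. Among the measured compounds shown here, no measured pair shows this change alone. Compound 3, which also has a ring with a hetero atom on its carbonyl, gives the weaker 200 nM, but it differs elsewhere too, so it is only a faint guide. A small expected step toward weaker inhibition, a 1.4-fold higher number from compound 2 to compound 4 (0.15 log units; within the scatter), would stay within the scatter. For compound 4 the estimated value is 120 nM, with an expected range of 40 nM to 350 nM.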

Compound 4, half-maximal inhibitory concentration: 75 nM
Compound 4: the middle estimate sits 1.6-fold (0.20 log units) above what was measured; the measured number falls inside the stated range.
By their numbers in this assay, from the lowest: compound 1; then compounds 4 and 2 (each within the scatter of the next); then compound 3.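

In this assay, among the compounds shown here, pyridin-3-yl in place of 4-fluorophenyl on a carbonyl carbon gives a 1.1-fold lower number from compound 2 to compound 4 (0.05 log units; within the scatter), the first step that can be read at this position. This carbonyl carbon therefore accepts a ring with a hetero atom and a hydrogen-bond acceptor in place of a carbon-only ring, with no shift beyond the scatter. Nothing measured here explains why the two groups read alike. From the compounds shown here alone, whether a piperidine ring or a plain methyl on this carbonyl carbon would read the same remains open.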